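A few compounds are considered here, and "the series" means these few. Any claim that something is new, unique, unknown or untested is made for them only; others in the source may bear on it.

Of the compounds shown here, three built on one shared core have been measured in an ADME assay on the whole organism for cytotoxicity, with Artemia salina as the target, with a stated time of 24 h; a lower number here means that less compound is needed, a higher number that more compound is needed for the effect. Compound 1 `Cc1ccc(S(=O)(=O)NC(=O)Nc2ccccc2C(=O)/C=C/c2cccc(O)c2)cc1` gives 39.3 ug/mL, compound 2 `Cc1ccc(S(=O)(=O)NC(=O)Nc2ccccc2C(=O)/C=C/c2ccc(O)cc2)cc1` gives 24.3 ug/mL, and compound 3 `Cc1ccc(S(=O)(=O)NC(=O)Nc2ccccc2C(=O)/C=C/c2ccccc2[N+](=O)[O-])cc1` gives 40.1 ug/mL. Compound 3 carries the highest of the three numbers, yet the steps of a 1.0-fold higher number from compound 1 to compound 3 (0.01 log units; within the scatter) and a 1.7-fold higher number from compound 2 to compound 3 (0.22 log units; within the scatter) both lie within the scatter, so no real separation between these compounds can be claimed. Compound 4 `Cc1ccc(S(=O)(=O)NC(=O)Nc2ccccc2C(=O)/C=C/c2ccc(Cl)cc2)cc1` differs from compound 3 by 4-chlorophenyl in place of 2-nitrophenyl on a double-bonded chain carbon bound to a double-bonded chain carbon. Every measured exchange of the group at this place, including a 1.6-fold lower number from compound 1 to compound 2 (0.21 log units; within the scatter), left the number within the scatter. In this assay the expected step is therefore a 1.1-fold lower number from compound 3 to compound 4 (0.06 log units; within the scatter), nothing beyond the scatter. Compound 4 is estimated at 35 ug/mL, within a range from 18 ug/mL to 70 ug/mL.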

Compound 4, concentration for half-maximal effect: 6.92 ug/mL
The estimate for compound 4 lay 5.1-fold (0.70 log units) above the measured number, outside the stated range (below it).
By their numbers in this assay, from the lowest: compound 4; then compounds 2, 1 and 3 (each within the scatter of the next).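

In this assay this position is not indifferent after all: 4-chlorophenyl brings a 5.8-fold lower number from compound 3 to compound 4 (0.76 log units; beyond the scatter) and a 5.7-fold lower number from compound 1 to compound 4 (0.75 log units; beyond the scatter) when it replaces the other groups. The cleanest comparison, chloro in place of hydroxy on an aromatic carbon, gives a 3.5-fold lower number from compound 2 to compound 4 (0.55 log units; beyond the scatter) with the rest of the molecule unchanged, so this one exchange moves the number beyond the scatter, as no exchange among compounds 1, 2 and 3 did. Nothing available here explains why.

On these data alone, whether chloro is special remains open. Compounds carrying 4-bromophenyl, 4-methylphenyl or 4-aminophenyl at this place would show whether the lower number is specific to chlorine.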